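The source may report more compounds than this note shows. Statements on the series, on what has been measured and on what is new or still open speak of the compounds shown alone.

Within the data shown here, the two compounds measured so far share one core and differ only in the group attached to an aromatic carbon of it. Compound 1 `NC(=O)c1cn([C@@H]2O[C@H](CO)[C@@H](O)[C@H]2O)nn1` carries a carbamoyl group there. In a functional assay on MOLT-4 cells (Homo sapiens) (on this read-out lower numbers stand for stronger inhibition and higher numbers for weaker inhibition), compound 1 gives only a limit, > 200000 nM. Compound 2 `CC(O)c1cn([C@@H]2O[C@H](CO)[C@@H](O)[C@H]2O)nn1` carries a 1-hydroxyethyl group instead. In this assay compound 2 also gives only a limit, > 200000 nM. The change from compound 1 to compound 2 is thus a step that the two limits leave unreadable from compound 1 to compound 2, and both values sit at the limit of > 200000 nM in this assay, at which 2 of the 2 values shown sit, so neither the size nor the direction of that change can be read.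

Compound 3 `OC[C@H]1O[C@@H](n2cc(-c3ccccn3)nn2)[C@H](O)[C@@H]1O` is the next variation on the same core, differing from compound 2 by pyridin-2-yl in place of 1-hydroxyethyl on an aromatic carbon. Among the measured compounds shown here, the only measured step, a step that the two limits leave unreadable from compound 1 to compound 2, gives no readable size, so it offers no direction to expect for this new change either. The step from compound 2 to compound 3 is therefore expected to be a number no higher from compound 2 to compound 3 (the limit leaves the size open). Compound 3 is estimated in this assay at 200000 nM, within a range from 50000 nM to 600000 nM, with a real chance that only a limit is reported once more.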

Compound 3, half-maximal inhibitory concentration: 170000 nM
Beside the measured number, compound 3's estimate is 1.2-fold (0.07 log units) above it, within the range that was stated.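

In this assay compound 3, with pyridin-2-yl on this aromatic carbon, gives a measured number, 170000 nM. As far as these compounds go, the change reads as an at least 1.1-fold lower number from compound 2 to compound 3 (0.07 log units; that floor lies within the scatter), and the replacement of carbamoyl reads as an at least 1.1-fold lower number from compound 1 to compound 3 (0.07 log units; that floor lies within the scatter); both are only floors, so the true size of each gap remains unknown and may be small. Among the compounds shown, a measured number appears only with the pyridin-2-yl group, while compound 1 and compound 2 each remain at a limit: the limit of > 200000 nM in this assay, at which 2 of the 3 values shown sit.

The compounds shown do not reveal whether that measured number goes with the six-membered aromatic ring as a whole or with its ring nitrogen, a question that a phenyl group at the same carbon could help to separate. They also leave open how other groups at this carbon, such as an amine, a carboxylic acid or a longer alkyl chain, would behave, and whether any group here could bring the number far down.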